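The source may hold more compounds than are shown below. What is called first, only, known or untested is meant among the compounds shown, and "the series" means these compounds.

Working notes on the series. Compound 1 `CC(O)(C(=O)Nc1ccc(S(=O)(=O)c2ccc(F)cc2)cc1)C(F)(F)F`, compound 2 `CC(O)(C(=O)Nc1ccc(C(=O)c2ccccc2)cc1Cl)C(F)(F)F` and compound 3 `CC(O)(C(=O)Nc1ccc(C(O)c2ccccc2)cc1)C(F)(F)F` share one core and were compared in a functional assay (Cavia porcellus) with sulfonylurea receptors; K-ATP channels (Homo sapiens) as the target; on this read-out higher numbers stand for weaker inhibition and lower numbers for stronger inhibition. For the measured compounds named here, compound 1 gives 8600 nM and is the only member with a number rather than a limit. For compound 2 this assay reports only a limit, > 30000 nM. For compound 3 likewise only a limit is reported, > 30000 nM. The numbers therefore offer little gradient: the limit of > 30000 nM in this assay, at which 2 of the 3 values shown sit. Compound 4 `CC(O)(C(=O)Nc1ccc(S(=O)(=O)c2ccccn2)cc1)C(F)(F)F` has not been measured; it differs from compound 1 by pyridin-2-yl in place of 4-fluorophenyl on a sulfonyl sulfur. Going by the values given here, with no measured step to lean on, the step in this assay is expected to be small, if anything toward weaker inhibition: a 1.4-fold higher number from compound 1 to compound 4 (0.14 log units; within the scatter). Compound 4 is accordingly expected near 12000 nM, between 4000 nM and 40000 nM in this assay.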

Compound 4, half-maximal inhibitory concentration: 600 nM
Estimate against measurement, compound 4: 20-fold (1.30 log units) above; the whole stated range lies above it.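

In this assay, pyridin-2-yl in place of 4-fluorophenyl on a sulfonyl sulfur gives a 14-fold lower number from compound 1 to compound 4 (1.16 log units; beyond the scatter). For the compounds shown here, this is the first step that changes one place only, and it shows that the group on the sulfonyl sulfur strongly affects the read-out. The rest of the series still offers little gradient: the limit of > 30000 nM in this assay, at which 2 of the 4 values shown sit.

The change adds a ring nitrogen and removes the fluorine, so the compounds shown do not separate these two contributions. On these data alone, how pyridin-3-yl or pyrimidin-2-yl on the same sulfur would read out also remains open.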